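A few compounds are considered here, and "the series" means these few. Any claim that something is new, unique, unknown or untested is made for them only; others in the source may bear on it.

Among the compounds with values here, in a functional assay on MDA-MB-436 cells (Homo sapiens) for antiproliferative activity, read by MTT assay, with a stated time of 24 h (a lower number here means a stronger inhibitor, a higher number a weaker inhibitor), compound 2 (`O=C(O)CC(NS(=O)(=O)c1ccccc1)c1ccc(Cl)cc1Cl`) gives 59000 nM, the only true number among the measured compounds. Compound 1 (`O=C(O)CC(NS(=O)(=O)c1cccc([N+](=O)[O-])c1)c1ccccc1`) reads > 100000 nM, which is a limit of the assay. Compound 3 (`O=C(O)CC(NS(=O)(=O)c1ccccc1Br)c1ccc(Cl)cc1Cl`) reads > 100000 nM, also a limit. Compound 4 (`O=C(O)CC(NS(=O)(=O)c1cccc([N+](=O)[O-])c1)c1ccc(Cl)cc1Cl`) differs from compound 2 by one change, nitro in place of hydrogen on an aromatic carbon. Within the data shown here, the only measured step of this kind, a bromo in place of hydrogen, is an at least 1.6-fold higher number from compound 2 to compound 3 (0.22 log units; that floor lies within the scatter), so it points weakly towards a higher number. Compound 1, which also bears a nitro group, stands at the limit of > 100000 nM in this assay, at which 2 of the 3 values shown sit. The expected change is small and upward, a 1.4-fold higher number from compound 2 to compound 4 (0.16 log units; within the scatter), and may not exceed the scatter. For compound 4 the estimate is 85000 nM, with an expected range of 40000 nM to 100000 nM.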

Compound 4, half-maximal inhibitory concentration: > 100000 nM
Compound 4 ended at the assay's limit; the forecaster's own chance of this, stated with the estimate: 55%; at least 1.1-fold (0.07 log units) between middle value and limit.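

The entering nitro group, on an aromatic carbon and meta to a large group, gives an at least 1.6-fold higher number from compound 2 to compound 4 (0.22 log units; that floor lies within the scatter). Compound 4 stands at a limit of the assay, so only a floor can be read for this step, and the step linking it to compound 1, also at a limit, cannot be read at all. Compound 2 therefore remains the only compound with a true number: the limit of > 100000 nM in this assay, at which 3 of the 4 values shown sit.

Going by these compounds, whether an amine or a methoxy group at this same place would give a true number remains open. So does how far compound 4 truly lies beyond its limit.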